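Moving a methoxy group around the benzyl ring

A few compounds are considered here, and "the series" means these few. Any claim that something is new, unique, unknown or untested is made for them only; others in the source may bear on it.

Compound 1: `CC(C)(C)c1ccc(CNCCCNS(=O)(=O)c2cc(C(F)(F)F)cc(C(F)(F)F)c2)cc1` gives 2500 nM
Compound 2: `COc1cccc(CNCCCNS(=O)(=O)c2cc(C(F)(F)F)cc(C(F)(F)F)c2)c1` gives 10000 nM
Compound 3: `COc1ccccc1CNCCCNS(=O)(=O)c1cc(C(F)(F)F)cc(C(F)(F)F)c1` gives 12000 nM

Three compounds share one core and differ only in the aryl group on a saturated chain carbon bound to an amine nitrogen. In a functional assay on PANC-1 cells (Homo sapiens) for inhibition, read by MTT assay, with a stated time of 72 h (a higher number here means a weaker inhibitor of growth, a lower number a stronger inhibitor of growth), compound 1 gives 2500 nM. Compound 2 stands second highest of the three numbers: its nearest neighbour is compound 3, and the step of a 1.2-fold higher number from compound 2 to compound 3 (0.08 log units; within the scatter) lies within the scatter, so the two cannot be told apart. Its furthest neighbour is compound 1, with the step of a 4.0-fold higher number from compound 1 to compound 2 (0.60 log units; beyond the scatter) beyond the scatter.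

Compound 4, `COc1ccc(CNCCCNS(=O)(=O)c2cc(C(F)(F)F)cc(C(F)(F)F)c2)cc1`, has not yet been measured. The change from compound 2 is 4-methoxyphenyl in place of 3-methoxyphenyl on a saturated chain carbon bound to an amine nitrogen. The step most like it is a 1.2-fold higher number from compound 2 to compound 3 (0.08 log units; within the scatter), which also shifted the methoxy group to another ring position and produced no change beyond the scatter. The step of a 4.8-fold higher number from compound 1 to compound 3 (0.68 log units; beyond the scatter) involves a different group and does not speak directly to this move. With one relevant step showing no real movement, the step of a 1.1-fold lower number from compound 2 to compound 4 (0.05 log units; within the scatter) is expected to stay within the scatter, with no clear direction. Compound 4 is therefore estimated at 9000 nM, within the range 3500 nM to 22000 nM.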

Compound 4, concentration for 50% growth inhibition: 11000 nM
Compound 4: middle estimate off by 1.2-fold (0.09 log units), on the low side, within the range that was stated.
By their numbers in this assay, from the lowest: compound 1; then compounds 2, 4 and 3 (each within the scatter of the next).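

With a 1.1-fold higher number from compound 2 to compound 4 (0.04 log units; within the scatter) and a 1.1-fold lower number from compound 3 to compound 4 (0.04 log units; within the scatter), the 4-methoxyphenyl group cannot be told apart from the 3-methoxyphenyl or 2-methoxyphenyl group in this assay, so moving the methoxy group around this ring gives no readable difference among compound 2, compound 3 and compound 4. What does register is the kind of group on the ring: methoxy in place of tert-butyl on an aromatic carbon gives a 4.4-fold higher number from compound 1 to compound 4 (0.64 log units; beyond the scatter), a change of group rather than of ring position, and it is of similar size to the steps from compound 1 to the other two methoxy compounds. The data shown offer no measurement that could explain either the lack of movement among the methoxy compounds or the step away from compound 1.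

The compounds shown leave open whether a smaller alkyl group such as methyl or isopropyl, or a halogen such as chlorine, on this ring would give numbers nearer to compound 1 or nearer to the methoxy compounds. They also leave open whether the same pattern would hold with a longer chain linking the amine to the sulfonamide.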